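The source may report more compounds than this note shows. Statements on the series, on what has been measured and on what is new or still open speak of the compounds shown alone.

Compound 1 `CCOC(=O)c1ccc(-c2nn(Cc3ccccn3)c3ccccc23)cc1`: in a functional assay on cells (Platelet, Homo sapiens) for inhibition (a higher number here means a weaker inhibitor, a lower number a stronger inhibitor), compound 1 gives > 10000 nM, which is a limit of the assay and not a number.
Compound 2 `CCOC(=O)c1ccc(-c2nn(Cc3cccnc3)c3ccccc23)cc1`: in this assay compound 2 gives > 10000 nM, again only a limit.
Compound 3 `CCOC(=O)c1ccc(-c2nn(Cc3ccncc3)c3ccccc23)cc1`: in this assay compound 3 gives > 10000 nM, likewise a limit.

Within the data shown here, compound 3 therefore stands where the whole series stands, at the limit of > 10000 nM in this assay, at which 3 of the 3 values shown sit, and no compound can be called stronger or weaker than another. The three steps between measured compounds, a step that the two limits leave unreadable from compound 1 to compound 2, a step that the two limits leave unreadable from compound 1 to compound 3 and a step that the two limits leave unreadable from compound 2 to compound 3, each swap the position of the ring nitrogen within the (pyridinyl)methyl group, and each is unreadable since both ends sit at the same limit.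

Compound 4 `CCOC(=O)c1ccc(-c2nn(-c3ccccc3)c3ccccc23)cc1` differs from compound 3 by phenyl in place of (pyridin-4-yl)methyl on an aromatic nitrogen. Among the measured compounds shown here, none of the measured steps bears directly on this change: they vary a ring nitrogen, not the linker or the ring type, and none gave a readable size. The shared core with the ethyl ester has shown no measurable inhibition with any of the three substituents tried, so compound 4 is expected to remain close to the limit, with a step that the limit leaves unreadable from compound 3 to compound 4 regarded as an estimate without a clear direction. Compound 4 is thus expected at 15000 nM, within a range of 3000 nM to 60000 nM, and most likely the assay will again report only a limit.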

Compound 4, half-maximal inhibitory concentration: > 10000 nM
Compound 4 ended at the assay's limit (the forecaster's own chance of this, stated with the estimate: 70%); the middle value is on the limit's open side.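

In this assay compound 4 gives > 10000 nM, which is a limit of the assay and not a number. Its steps from compound 1, compound 2 and compound 3 therefore cannot be read, because all four compounds sit at the same limit: the limit of > 10000 nM in this assay, at which 4 of the 4 values shown sit.

The compounds shown leave open whether any group on the aromatic nitrogen of the shared core changes inhibition.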